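The source may report more compounds than this note shows. Statements on the series, on what has been measured and on what is new or still open speak of the compounds shown alone.

Working notes on the amide series. Compound 1 `CCCCNC(=O)c1c(O)c2cccnc2n(-c2ccccc2)c1=O` gives 12.8% in a functional assay on the whole organism for inhibition, with Rattus norvegicus as the target, read by paw edema, at a dose of 100 mg/kg by the oral route; a lower number here means less inhibition, a higher number more inhibition at the dose given (going by the name of the read-out). Compound 2 `O=C(NC1CCN(Cc2ccccc2)CC1)c1c(O)c2cccnc2n(-c2ccccc2)c1=O` gives 1.7% in this assay, and compound 3 `COc1ccc(NC(=O)c2c(O)c3cccnc3n(-c3ccccc3)c2=O)cc1` gives 0.3%. For the measured compounds named here, compound 3 therefore holds the lowest of the three numbers so far: its nearest neighbour is compound 2, within the scatter, and its furthest is compound 1, beyond the scatter. Going by the values given here, the only measured step that reaches compound 3 is a number 12.5 percentage points lower from compound 1 to compound 3 (beyond the scatter), a modest drop on going from butyl to 4-methoxyphenyl on the amide-type nitrogen.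

The next member, compound 4 `Cc1ccccc1NC(=O)c1c(O)c2cccnc2n(-c2ccccc2)c1=O`, differs from compound 3 in one place: 2-methylphenyl in place of 4-methoxyphenyl on an amide-type nitrogen.

Which measured steps bear on this? The step from compound 1 to compound 3 exchanges a chain for an aromatic ring on that nitrogen and says little about swapping one aromatic group for another. Compound 2 and compound 3, which both carry a larger, ring-containing substituent on the amide-type nitrogen, sit within the scatter of each other. Among the compounds with values here, no measured step argues for a movement beyond the scatter in this assay.

The step of a number 3.7 percentage points higher from compound 3 to compound 4 (within the scatter) is accordingly expected to stay within the scatter. Compound 4 is estimated at 4%, with a range from 0% to 14%.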

Compound 4, a percentage reported as inhibition, in the whole organism at one dose (the size of the read-out at that dose, not a potency): 11.7%
For compound 4 the middle estimate is 7.7 percentage points below the measured one; the range from low to high includes it.
By their numbers in this assay, from the lowest: compounds 3, 2, 4 and 1 (each within the scatter of the next, the first and the last beyond it).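

In this assay, for the compounds shown here, the choice of aromatic group on the amide-type nitrogen turns out to matter: a number 11.4 percentage points higher from compound 3 to compound 4 (beyond the scatter) marks a movement beyond the scatter on exchanging 4-methoxyphenyl for 2-methylphenyl, whereas the earlier steps offered no comparison of one aromatic group with another. With a number 1.1 percentage points lower from compound 1 to compound 4 (within the scatter), the 2-methylphenyl group stays level with butyl, so the drop seen on replacing butyl with 4-methoxyphenyl does not follow from placing just any aromatic ring on this nitrogen. The data shown offer no explanation for the gap between these two aromatic groups.

The change from 4-methoxyphenyl to 2-methylphenyl alters both the substituent and its printed ring position, so the compounds shown cannot separate the two; a 2-methoxyphenyl or a 4-methylphenyl group on the same nitrogen would address that question directly. As far as these compounds go, how an unsubstituted phenyl or a 4-chlorophenyl group would read at this position also remains open.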